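From Pyrrole to Pyrrolidine in Bradykinin Receptor Ligands

A few compounds are considered here, and "the series" means these few. Any claim that something is new, unique, unknown or untested is made for them only; others in the source may bear on it.

Measured compounds:
compound 1 `COC(=O)C1=C(c2ccc(CNc3nccc(C)c3NC(=O)CC#N)cc2)CCCC1` gives 35 nM in an assay on isolated protein for binding affinity to B1 bradykinin receptor (Homo sapiens); a higher number here means a weaker inhibitor, a lower number a stronger inhibitor;
compound 2 `COC(=O)c1ccccc1N1CCC(C)(CNc2nccc(C)c2NC(=O)CC#N)CC1` gives 3500 nM in this assay;
compound 3 `COC(=O)c1cccn1-c1ccc(CNc2nccc(C)c2NC(=O)CC#N)cc1` gives 250 nM in this assay.

Compound 3 stands second highest of the three numbers, between compound 1 and compound 2. Compound 4 `COC(=O)C1CCCN1c1ccc(CNc2nccc(C)c2NC(=O)CC#N)cc1` differs from it by 2-(methoxycarbonyl)pyrrolidin-1-yl in place of 2-(methoxycarbonyl)-1H-pyrrol-1-yl on an aromatic carbon. Among the measured compounds shown here, the one measured step that touches this ring, a 7.1-fold higher number from compound 1 to compound 3 (0.85 log units; beyond the scatter), swaps one five-membered aromatic ring for a non-aromatic six-membered one, so it hints only loosely. For the measured compounds named here, compound 2, the only other compound carrying a saturated nitrogen ring, shows a high number, but its ring sits differently. The step of a 1.6-fold higher number from compound 3 to compound 4 (0.20 log units; within the scatter) is therefore expected to stay within the scatter, with wide uncertainty. Compound 4 is estimated at 400 nM, between 100 nM and 1600 nM.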

Compound 4, inhibition constant: > 5000 nM
Compound 4: a limit, no number; the forecaster's own chance of this, stated with the estimate: 5%; middle value at least 12-fold (1.09 log units) away from the limit.
By their numbers in this assay, from the lowest: compound 1; then compound 3; then compound 2. At a limit, above all of these: compound 4.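

The value of compound 4 is a limit of the assay, not a number: the limit of > 5000 nM in this assay, at which 1 of the 4 values shown sits. With the methoxycarbonyl group and the ring size unchanged, replacing the aromatic ring with a non-aromatic one gives an at least 20-fold higher number from compound 3 to compound 4 (1.30 log units; beyond the scatter) in this assay, so this position separates two rings with the same heavy-atom count. The cyclohexene-bearing compound also stands far ahead, with an at least 140-fold higher number from compound 1 to compound 4 (2.15 log units; beyond the scatter) on the same position. Open, on these data alone, is whether a carboxylic acid or an amide in place of the methyl ester would change the pyrrolidine's result.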